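This account rests on a few compounds, and the source may have more. Where it says the series, first, only, none or still open, it means among the compounds named here.

Within the data shown here, in a functional assay on cells (T-cell line, Homo sapiens) for inhibition (on this read-out higher numbers stand for weaker inhibition and lower numbers for stronger inhibition), compound 3 (`CCCCCN1CCC(COC(c2ccccc2)c2ccccc2)CC1`) gives 10800 nM, the highest of the three numbers measured so far. Compound 1 (`COc1ccccc1CCCN1CCC(COC(c2ccccc2)c2ccccc2)CC1`) gives 2400 nM, and compound 2 (`Clc1ccccc1CCCN1CCC(COC(c2ccccc2)c2ccccc2)CC1`) gives 800 nM. The move to compound 4 (`COc1ccc(/C=C/CN2CCC(COC(c3ccccc3)c3ccccc3)CC2)cc1`) is 2-(4-methoxyphenyl)ethenyl in place of butyl on a saturated chain carbon bound to an amine nitrogen in a ring, which brings an aromatic ring back onto the chain. Among the measured compounds shown here, two measured steps bear on this, both running the opposite way as an aromatic ring leaves: a 4.5-fold higher number from compound 1 to compound 3 (0.65 log units; beyond the scatter) and a 14-fold higher number from compound 2 to compound 3 (1.13 log units; beyond the scatter). For the measured compounds named here, no measured compound carries the double bond, so that part remains untested. A step to a lower number in this assay is therefore expected, estimated as a 6.0-fold lower number from compound 3 to compound 4 (0.78 log units; beyond the scatter). For compound 4 the expected value is 1800 nM, within an estimated range of 600 nM to 5500 nM.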

Compound 4, half-maximal inhibitory concentration: 4300 nM
For compound 4 the middle estimate is 2.4-fold (0.38 log units) below the measured one; the measured number falls inside the stated range.
By their numbers in this assay, from the lowest: compound 2; then compounds 1 and 4 (each within the scatter of the next); then compound 3.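

In this assay, 2-(4-methoxyphenyl)ethenyl on a saturated chain carbon bound to an amine nitrogen in a ring gives a lower number than butyl, a 2.5-fold lower number from compound 3 to compound 4 (0.40 log units; beyond the scatter), so an aromatic ring reached through a double bond also counts here. Set against 2-(2-chlorophenyl)ethyl the change gives a 5.4-fold higher number from compound 2 to compound 4 (0.73 log units; beyond the scatter), while against 2-(2-methoxyphenyl)ethyl it gives a 1.8-fold higher number from compound 1 to compound 4 (0.25 log units; within the scatter). No evidence on why these numbers move is available.

The compounds shown leave open what the double bond does alone, since the methoxy group also sits differently in compound 4. As far as these compounds go, how a carboxylic acid on that aromatic ring would read also stays open.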